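A few compounds are considered here, and "the series" means these few. Any claim that something is new, unique, unknown or untested is made for them only; others in the source may bear on it.

Compound 3 `CC(C)(C)Cc1c(-c2c(F)cccc2F)sc(N)c1C(=O)c1ccc(Cl)cc1` gives 1% in an assay on CHO cells for displacement of a labelled ligand from adenosine receptor A3 (Homo sapiens), read by scintillation counting, tested at 10 uM; on this read-out lower numbers stand for less inhibition and higher numbers for more inhibition at the one concentration tested (going by the name of the read-out). It stands level with compound 2 `CC(C)(C)Cc1c(-c2cccc(F)c2F)sc(N)c1C(=O)c1ccc(Cl)cc1`, which gives 1%, and together these are the lowest of the three numbers; compound 1 `CC(C)(C)Cc1c(-c2ccc(F)cc2)sc(N)c1C(=O)c1ccc(Cl)cc1` gives 9%. The step of a number 8 percentage points lower from compound 1 to compound 3 (within the scatter) and the step of no change at the digits printed from compound 2 to compound 3 (within the scatter) both lie within the scatter. Compound 4 `CC(C)(C)Cc1c(-c2ccc(Cl)c(Cl)c2)sc(N)c1C(=O)c1ccc(Cl)cc1` differs from compound 3 by 3,4-dichlorophenyl in place of 2,6-difluorophenyl on an aromatic carbon. Going by the values given here, the two measured steps that lead into compound 3 only rearrange fluorine atoms on that phenyl ring and stay within the scatter; no measured step exchanges fluorine for chlorine, so nothing shows what chlorine does here. The step of a number 3 percentage points higher from compound 3 to compound 4 (within the scatter) is therefore expected to remain within the scatter. Compound 4 is estimated at 4%, with a range from 0% to 16%.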

Compound 4, a percentage reported as inhibition, at one concentration (the size of the read-out at that concentration, not a potency): 1%
For compound 4 the middle estimate is 3 percentage points above the measured one; the range from low to high includes it.
By their numbers in this assay, from the lowest: compounds 2, 3, 4 and 1 (each within the scatter of the next).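

All three new steps lie within the scatter: no change at the digits printed from compound 3 to compound 4 (within the scatter), no change at the digits printed from compound 2 to compound 4 (within the scatter) and a number 8 percentage points lower from compound 1 to compound 4 (within the scatter). The 3,4-dichlorophenyl group, with chlorine where the earlier phenyl groups carry fluorine, therefore cannot be told apart from them in this assay. Nothing measured here offers an explanation for this result.

Every compound shown has a halogen-bearing phenyl group at this position, so it remains open whether an amine, a carboxylic acid or a longer chain there would give a higher number in this assay. As far as these compounds go, the neopentyl, amino and (4-chlorophenyl)carbonyl groups stay the same throughout, so their contributions also remain open.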